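A few compounds are considered here, and "the series" means these few. Any claim that something is new, unique, unknown or untested is made for them only; others in the source may bear on it.

Three compounds share one core and differ only in the aryl group attached to the double-bonded chain carbon bound to an aromatic carbon. Compound 1 `C=CCn1c(=O)/c(=C\c2ccccc2Cl)[nH]c(=O)/c1=C\c1ccccc1OC` gives 4200 nM in a functional assay on HL-60 cells (Homo sapiens) for cytotoxicity, read by CCK-8 assay, with a stated time of 72 h; on this read-out higher numbers stand for weaker inhibition and lower numbers for stronger inhibition. Compound 2 `C=CCn1c(=O)/c(=C\c2cccc(Br)c2)[nH]c(=O)/c1=C\c1ccccc1OC` gives 5200 nM in this assay, and compound 3 `C=CCn1c(=O)/c(=C\c2ccccc2C(F)(F)F)[nH]c(=O)/c1=C\c1ccccc1OC` gives 4600 nM. On these three numbers compound 3 stands second highest, with compound 1 nearest and compound 2 furthest; both gaps are within the scatter.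

Compound 4 `C=CCn1c(=O)/c(=C\c2cccc(C)c2)[nH]c(=O)/c1=C\c1ccccc1OC` has not yet been measured. It differs from compound 3 in one place: 3-methylphenyl in place of 2-(trifluoromethyl)phenyl on a double-bonded chain carbon bound to an aromatic carbon.

The steps already measured all concern swaps of this aryl group and all fall within the scatter: a 1.2-fold higher number from compound 1 to compound 2 (0.09 log units; within the scatter), a 1.1-fold higher number from compound 1 to compound 3 (0.04 log units; within the scatter) and a 1.1-fold lower number from compound 2 to compound 3 (0.05 log units; within the scatter). Neither moving a halogen from one position of the ring to another nor exchanging chloro for trifluoromethyl has shifted the read-out beyond its noise. Among the measured compounds shown here, no measured step covers a methyl group, so the effect of 3-methylphenyl itself is unknown here, and the expectation rests on how little the aryl group has mattered so far.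

Compound 4 is therefore expected to show no step beyond the scatter, a 1.0-fold higher number from compound 3 to compound 4 (0.02 log units; within the scatter), and its estimated value in this assay is 4800 nM, within a range from 2200 nM to 10500 nM.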

Compound 4, half-maximal inhibitory concentration: 16700 nM
Compound 4: the middle estimate sits 3.5-fold (0.54 log units) below what was measured; measured number outside the range, above it.
By their numbers in this assay, from the lowest: compounds 1, 3 and 2 (each within the scatter of the next); then compound 4.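

The aryl group on this double-bonded chain carbon is less indifferent than compounds 1 to 3 suggested: in this assay there is a 3.6-fold higher number from compound 3 to compound 4 (0.56 log units; beyond the scatter) with 3-methylphenyl entering, alongside a 3.2-fold higher number from compound 2 to compound 4 (0.51 log units; beyond the scatter) and a 4.0-fold higher number from compound 1 to compound 4 (0.60 log units; beyond the scatter) as the two further steps, all of them beyond the scatter. The step from compound 2 matters most for reading the change, since the 3-bromophenyl of compound 2 stays within the scatter of compound 1 and compound 3, whereas exchanging its bromo for methyl gives a clearly weaker result, so the numbered ring place alone does not set compound 4 apart from the others. Among these four compounds, 3-methylphenyl is also the only aryl group without a halogen atom, but no measurement available here explains why this group differs from the others.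

The compounds shown leave open whether the loss follows methyl specifically or the absence of halogen, and an unsubstituted phenyl or an ethyl group on this ring would bear on that. They also leave open how an amine or a carboxylic acid at this aryl group would read in this assay and whether any such group could improve on the halogen-bearing compounds.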